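Swapping methoxy for fluoro on a bisarylidene diketopiperazine

A few compounds are considered here, and "the series" means these few. Any claim that something is new, unique, unknown or untested is made for them only; others in the source may bear on it.

Measured compounds:
- compound 1, `C=CCn1c(=O)/c(=C\c2ccc(F)c(Br)c2)[nH]c(=O)/c1=C\c1ccccc1OC`: "not active" (no number reported)
- compound 2, `C=CCn1c(=O)/c(=C\c2cccc(Br)c2)[nH]c(=O)/c1=C\c1ccccc1OC`: 5000 nM
- compound 3, `C=CCn1c(=O)/c(=C\c2ccccc2OC)[nH]c(=O)/c1=C\c1ccccc1OC`: 13100 nM

Of the compounds shown here, three sharing one core have been tested in a functional assay on MOLT-4 cells (Homo sapiens) for cytotoxicity, read by CCK-8 assay, with a stated time of 72 h; a higher number here means a weaker inhibitor, a lower number a stronger inhibitor. Compound 1 was reported as "not active" (no number reported), with no number given. Compound 2 gives 5000 nM, and compound 3 gives 13100 nM. Among the two numbers, compound 3 stands highest, which here means it is the weaker inhibitor of the pair; the only measured step, a 2.6-fold higher number from compound 2 to compound 3 (0.42 log units; beyond the scatter), is modest but beyond the usual scatter.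

Compound 4, `C=CCn1c(=O)/c(=C\c2ccccc2F)[nH]c(=O)/c1=C\c1ccccc1OC`, has not yet been measured. It differs from compound 3 in one place: fluoro in place of methoxy on an aromatic carbon. Within the data shown here, no measured step covers this exact exchange of fluoro for methoxy; the one step available concerns a different aryl group in the same position, so it says nothing direct about compound 4. Without a bearing step, the expectation is that the change stays within the scatter, with no clear direction. Compound 4 is therefore estimated at 12000 nM, within a range of 4000 nM to 40000 nM, which means an expected step of a 1.1-fold lower number from compound 3 to compound 4 (0.04 log units; within the scatter).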

Compound 4, half-maximal inhibitory concentration: 20000 nM
The estimate for compound 4 lay 1.7-fold (0.22 log units) below the measured number, within the range that was stated.
By their numbers in this assay, from the lowest: compound 2; then compounds 3 and 4 (each within the scatter of the next).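

In this assay, a 1.5-fold higher number from compound 3 to compound 4 (0.18 log units; within the scatter) shows that methoxy and fluoro cannot be told apart at this aromatic carbon, ortho to a large group, even though the smaller fluoro brings no hydrogen-bond acceptor and replaces a group of two heavy atoms. The earlier compounds could not show this, as their only step changed the whole aryl group, and the new comparison with 3-bromophenyl now gives a 4.0-fold higher number from compound 2 to compound 4 (0.60 log units; beyond the scatter), beyond the scatter, alongside a 2.6-fold higher number from compound 2 to compound 3 (0.42 log units; beyond the scatter), so among these three numbers both 2-substituted phenyl groups give a higher number than 3-bromophenyl, while compound 1 has no number and can neither support nor oppose this pattern. No measurement at hand explains why these numbers fall as they do.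

The compounds shown leave open whether this position would respond to a group of a different kind, such as an amine or a carboxylic acid, in place of fluoro or methoxy. They also leave open whether 2-bromophenyl would give a number like that of compound 4 or like that of compound 2, which would help separate the effect of the group from that of its place on the ring.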